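The source may report more compounds than this note shows. Statements on the series, on what has been measured and on what is new or still open speak of the compounds shown alone.

Measured in an ADME assay on microsomes from liver (Homo sapiens) for metabolic stability, with a stated time of 60 min, tested at 1 uM; on this read-out lower numbers stand for a less stable compound and higher numbers for a more stable compound:
- compound 1 `CS(=O)(=O)Nc1ccc2c(c1)S(=O)(=O)N=C(C1=C(O)[C@@H]3[C@H]4CC[C@H](C4)[C@@H]3N(Cc3ccccc3)C1=O)N2`: 80%
- compound 2 `COc1cccc(CN2C(=O)C(C3=NS(=O)(=O)c4cc(NS(C)(=O)=O)ccc4N3)=C(O)[C@@H]3[C@H]4CC[C@H](C4)[C@@H]32)c1`: 61%
- compound 3 `Cc1ccc(CN2C(=O)C(C3=NS(=O)(=O)c4cc(NS(C)(=O)=O)ccc4N3)=C(O)[C@@H]3[C@H]4CC[C@H](C4)[C@@H]32)cc1F`: 78%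

Compound 1 holds the top number of the three, but only the gap to compound 2 counts: a number 19 percentage points lower from compound 1 to compound 2 (beyond the scatter), while a number 2 percentage points lower from compound 1 to compound 3 (within the scatter).

Compound 4 `CS(=O)(=O)Nc1ccc2c(c1)S(=O)(=O)N=C(C1=C(O)[C@@H]3[C@@H]4CC[C@@H](C4)[C@@H]3N(Cc3ccccc3)C1=O)N2` is next, set against compound 1: the two compounds have the same atoms and bonds and differ only in configuration as drawn: 2 of 4 stereo elements differ; a stereocentre at a saturated ring carbon is drawn S in compound 1 and R in compound 4; a stereocentre at a saturated ring carbon is drawn R in compound 1 and S in compound 4.

Within the data shown here, none of the measured steps alters configuration. All concern the aromatic ring on the saturated chain carbon, so they offer only a guide to size, with a number 17 percentage points higher from compound 2 to compound 3 (beyond the scatter) as the other step. The data give no firm direction for a change of configuration, and a small step is expected, with a wide margin. The expected outcome is a number 6 percentage points lower from compound 1 to compound 4 (within the scatter). For compound 4 the estimate is 74%, with an expected range of 52% to 90%.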

Compound 4, percent of the compound remaining: 90%
Compound 4: middle estimate off by 16 percentage points, on the low side, within the range that was stated.
By their numbers in this assay, from the lowest: compound 2; then compounds 3, 1 and 4 (each within the scatter of the next, the first and the last beyond it).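

Changing the configuration as drawn at two saturated ring carbons is the only step shown that leaves the aromatic ring untouched, and in this assay it gives a number 10 percentage points higher from compound 1 to compound 4 (within the scatter). This change therefore has no effect that can be told from the scatter. The comparison isolates configuration alone: the fact that compounds 1 and 4 differ only in the configuration as drawn

Still open, on these data alone, is whether 3-methoxyphenyl and 3-fluoro-4-methylphenyl would read the same on the configuration of compound 4. Also open, as far as these compounds go, is how an amine or a carboxylic acid on that aromatic ring would read in this assay.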